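The source may hold more compounds than are shown below. What is called first, only, known or untested is meant among the compounds shown, and "the series" means these compounds.

Compound 3 `CNC(=O)CCc1ccncc1-c1ccc2ccccc2c1` is one of three compounds tested in a functional assay on KB cells (Homo sapiens) for inhibition, read by sulforhodamine B assay, with a stated time of 72 h; a higher number here means a weaker inhibitor of growth, a lower number a stronger inhibitor of growth. Compound 3 gives > 10000 nM, which is a limit of the assay rather than a number. Compound 1 `NC(=O)/C=C/c1ccncc1-c1ccc2ccccc2c1` gives > 10000 nM, again a limit. Compound 2 `Cn1ccc2cc(-c3cnccc3/C=C/C(=O)O)ccc21` gives > 10000 nM, also a limit. All three values sit at the same limit, (the limit of > 10000 nM in this assay, at which 3 of the 3 values shown sit), so none can be ranked against the others.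

Compound 4 `CNC(=O)/C=C/c1ccncc1-c1ccc2ccccc2c1` has not been measured. It differs from compound 3 in one place: 2-(methylcarbamoyl)ethenyl in place of 2-(methylcarbamoyl)ethyl on an aromatic carbon. Going by the values given here, the only measured step that touches the same region of the molecule is the one from compound 1 to compound 3, a step that the two limits leave unreadable from compound 1 to compound 3, so its size is not readable. Because compound 1 gives > 10000 nM and compound 3 gives > 10000 nM, there is no evidence in this assay that the chain, saturated or not, moves the result off the limit.

Compound 4 is therefore expected to stay at the limit, with an estimated step that the limit leaves unreadable from compound 3 to compound 4. The estimate for compound 4 is 20000 nM, with a range from 7000 nM to 60000 nM.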

Compound 4, concentration for 50% growth inhibition: > 10000 nM
Compound 4 was reported as a limit (the forecaster's own chance of this, stated with the estimate: 85%); the middle value lies beyond the limit too.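

The steps from compound 3 to compound 4 and from compound 1 to compound 4 cannot be read, because each joins two limits: the limit of > 10000 nM in this assay, at which 4 of the 4 values shown sit. The compounds shown leave open which change to the shared core, if any, would give a readable number in this assay rather than a limit.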